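Swapping fluoro for methoxy on the aryl piperazine

A few compounds are considered here, and "the series" means these few. Any claim that something is new, unique, unknown or untested is made for them only; others in the source may bear on it.

Of the compounds shown here, three sharing one core have been tested in an assay on HEK293 cells for inhibition of Voltage-dependent T-type calcium channel subunit alpha-1G (Homo sapiens), read by fluorescence, tested at 10 uM; a lower number here means less inhibition, a higher number more inhibition at the concentration tested (going by the name of the read-out). Compound 1 `CCCc1nc(-c2ccccc2)c(CNCCCN2CCN(c3ccc(F)cc3)CC2)o1` gives 62.5%, compound 2 `CCCc1nc(-c2ccccc2)c(CNCCCN2CCN(c3cccc(C(F)(F)F)c3)CC2)o1` gives 51.6%, and compound 3 `CCCc1nc(-c2ccccc2)c(CNCCCN2CCN(c3cccc(F)c3)CC2)o1` gives 68.9%. Compound 3 holds the highest of the three numbers, though its lead over compound 1 is small: a number 6.4 percentage points higher from compound 1 to compound 3 (within the scatter). Its lead over compound 2 is clearer, since a number 17.3 percentage points higher from compound 2 to compound 3 (beyond the scatter), and likewise a number 10.9 percentage points lower from compound 1 to compound 2 (beyond the scatter).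

Compound 4 `CCCc1nc(-c2ccccc2)c(CNCCCN2CCN(c3cccc(OC)c3)CC2)o1` is not yet measured. It differs from compound 3 in one place: methoxy in place of fluoro on an aromatic carbon. Among the compounds with values here, the step that bears most directly on this is the one from compound 2 to compound 3, where a fluoro also replaced a trifluoromethyl on an aromatic carbon and the number moved by a modest amount. The step from compound 1 to compound 3 stayed within the scatter. A small group on the same aromatic carbon has so far given a number near the top of this set, and a methoxy is only slightly larger than a fluoro, so compound 4 is expected to stay close, with a number 6.9 percentage points lower from compound 3 to compound 4 (within the scatter). The estimate for compound 4 in this assay is 62%, between 46% and 78%.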

Compound 4, a percentage reported as inhibition, at one concentration (the size of the read-out at that concentration, not a potency): 36.4%
Beside the measured number, compound 4's estimate is 25.6 percentage points above it; measured number below the stated range.
By their numbers in this assay, from the lowest: compound 4; then compound 2; then compounds 1 and 3 (each within the scatter of the next).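

In this assay, the change from 3-fluorophenyl to 3-methoxyphenyl gives a number 32.5 percentage points lower from compound 3 to compound 4 (beyond the scatter), showing that a swap of one fluorine for one carbon and one oxygen on this aromatic carbon lowers the number far more than the earlier, closely grouped numbers suggested. The earlier compounds shown here had placed trifluoromethyl at the bottom of the set, but methoxy now sits lower still, with a number 15.2 percentage points lower from compound 2 to compound 4 (beyond the scatter), and the comparison with the 4-fluorophenyl compound points the same way, with a number 26.1 percentage points lower from compound 1 to compound 4 (beyond the scatter), so compound 4 has the lowest number of the four. No measurement shown here explains why methoxy behaves this way at this position.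

The compounds shown do not settle whether the drop follows from the oxygen or from the methyl carried on it, and a hydroxyl or an ethyl on the same aromatic carbon would help separate the two. On these data alone, it also remains open how far these differences at a single tested concentration reflect differences in potency, and whether methoxy would have the same effect on another carbon of this aromatic ring.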